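Methoxy to trifluoromethoxy on two related cores

The source may hold more compounds than are shown below. What is called first, only, known or untested is meant among the compounds shown, and "the series" means these compounds.

Three compounds are measured in an assay on isolated protein for inhibition of DNA topoisomerase 1 (Homo sapiens), with a stated time of 30 min, tested at 20 uM; on this read-out lower numbers stand for a weaker effect and higher numbers for a stronger effect at the one concentration tested. Compound 1 `COc1cccc(-c2nc3ccc(C)cc3c(=O)[nH]2)c1` gives 0%, and compound 2 `Cc1ccc2nc(-c3cccc(OC(F)(F)F)c3)[nH]c(=O)c2c1` gives 0%. The two differ in one place, (trifluoromethyl in place of methyl on an oxygen on an aromatic ring), and the step of no change at the digits printed from compound 1 to compound 2 (within the scatter). Compound 3 `COc1cccc(-c2nc3cc(C)ccc3c(=O)[nH]2)c1` gives 80%, the highest of the three numbers, with compound 1 and compound 2 each standing well beyond the scatter below it. Compound 3 and compound 1 are built from the same atoms joined differently; the difference between the two cores is not broken down here.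

Compound 4 `Cc1ccc2c(=O)[nH]c(-c3cccc(OC(F)(F)F)c3)nc2c1` is not yet measured. It differs from compound 3 by trifluoromethyl in place of methyl on an oxygen on an aromatic ring, the same change as between compound 1 and compound 2, made on the core of compound 3 rather than that of compound 1. Within the data shown here, the earlier step from compound 1 to compound 2 started from no measurable inhibition, so it shows only that the change did not raise a flat read-out; it says little about what happens from a high starting point. On that limited footing, compound 4 is expected to keep a good part of the inhibition of compound 3, with the estimated step of a number 15 percentage points lower from compound 3 to compound 4 (beyond the scatter) in this assay. The estimate for compound 4 is 65%, with a range from 30% to 90%, wide because this change is informed only by compound 1 with 0% and by compound 2 with 0%.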

Compound 4, a percentage reported as inhibition, at one concentration (the size of the read-out at that concentration, not a potency): 0%
Estimate against measurement, compound 4: 65 percentage points above; the whole stated range lies above it.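

Methoxy to trifluoromethoxy costs the whole read-out on the one core that shows any inhibition, with a number 80 percentage points lower from compound 3 to compound 4 (beyond the scatter) in this assay. The change therefore does not carry over unchanged from one core to the other: the same change on two cores in this assay, no change at the digits printed (within the scatter) from compound 1 to compound 2 and a number 80 percentage points lower (beyond the scatter) from compound 3 to compound 4, 80 percentage points apart, beyond the scatter of two such steps

This does not establish how the change would act on an active compound of the other core: the flat step starts from compound 1 at 0%, a read-out with no room to fall. Each step also rests on a single pair at a single concentration, which gives no measure of potency and no account of why the change acts as it does.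

The compounds shown leave open whether the loss is particular to trifluoromethoxy or follows from almost any replacement of methoxy on the core of compound 3. An ethoxy, a chlorine or an amine in that place would show whether any other group keeps the inhibition of compound 3.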